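A few compounds are considered here, and "the series" means these few. Any claim that something is new, unique, unknown or untested is made for them only; others in the source may bear on it.

Working notes on the series in a functional assay on A549 cells (Homo sapiens) for cytotoxicity; a higher number here means a weaker inhibitor, a lower number a stronger inhibitor. For the measured compounds named here, compound 1 `C=C/C=C\[C@H](C)[C@H](OC(N)=O)[C@@H](C)[C@H](O)[C@@H](C)C/C(C)=C\[C@H](C)[C@@H](O)[C@@H](C)/C=C\CCc1ccc(C)c(O)c1` gives 4000 nM, the higher of the two numbers so far, and compound 2 `C=C/C=C\[C@H](C)[C@H](OC(N)=O)[C@@H](C)[C@H](O)[C@@H](C)C/C(C)=C\[C@H](C)[C@@H](O)[C@@H](C)/C=C\CCc1cccc(OC)c1` gives 600 nM. The open case is compound 3 `C=C/C=C\[C@H](C)[C@H](OC(N)=O)[C@@H](C)[C@H](O)[C@@H](C)C/C(C)=C\[C@H](C)[C@@H](O)[C@@H](C)/C=C\CCc1ccsc1`, which keeps the core of compound 1 and carries thiophen-3-yl in place of 3-hydroxy-4-methylphenyl on a saturated chain carbon, two bonds along the chain from a double-bonded chain carbon.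

Going by the values given here, only one measured step bears on this change. It is a 6.7-fold lower number from compound 1 to compound 2 (0.82 log units; beyond the scatter), a modest step beyond the scatter, in which the same 3-hydroxy-4-methylphenyl leaves from the same place. Among the compounds with values here, that step ends in another six-membered ring, so no measured compound covers a five-membered aromatic ring here, and a single step is thin ground. Within the data shown here, a lower number than that of compound 1 is still expected, with a shift probably smaller than the one seen for compound 2 at 600 nM. The expected step is a 4.0-fold lower number from compound 1 to compound 3 (0.60 log units; beyond the scatter). For compound 3 the estimated value is 1000 nM, with an expected range of 300 nM to 3500 nM.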

Compound 3, half-maximal inhibitory concentration: 4000 nM
Compound 3: middle estimate off by 4.0-fold (0.60 log units), on the low side; measured number above the stated range.
By their numbers in this assay, from the lowest: compound 2; then compounds 1 and 3 (each within the scatter of the next).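

In this assay, the departure of 3-hydroxy-4-methylphenyl does not by itself lower the number at this position on the saturated chain carbon: thiophen-3-yl in its place gives no change at the digits printed from compound 1 to compound 3 (within the scatter). The step from the other measured analogue is a 6.7-fold higher number from compound 2 to compound 3 (0.82 log units; beyond the scatter), so of the two groups tried in place of 3-hydroxy-4-methylphenyl, only 3-methoxyphenyl goes with a number beyond the scatter of compound 1, and the result at this position depends on which group enters, not only on which group leaves. Nothing in hand explains why the entering groups differ in this way.

Compound 2 and compound 3 differ both in ring size and in the methoxy group, so the compounds shown cannot say which of the two goes with the lower number of compound 2. An unsubstituted phenyl ring or a methoxy-bearing thiophen-3-yl at this place would separate the two, while a 3-aminophenyl group would show whether the methoxy oxygen can be replaced by an amine.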